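From acetoxy to (furan-2-yl)oxy: notes on one step

The source may hold more compounds than are shown below. What is called first, only, known or untested is meant among the compounds shown, and "the series" means these compounds.

Among the compounds with values here, in a functional assay on KB cells (Homo sapiens) for cytotoxicity (on this read-out higher numbers stand for weaker inhibition and lower numbers for stronger inhibition), only two compounds have numbers so far. Compound 1 (`CC(=O)OC1=CC(=O)c2ccccc2C1=O`) gives 38800 nM here, and compound 2 (`CCOc1ccc2c(c1)C(=O)C=CC2=O`) gives 21400 nM in the same read-out. These two values lie within the scatter of each other, so compound 1 stands level with compound 2 and neither can be ranked.

Compound 3 (`O=C1C=C(Oc2ccco2)C(=O)c2ccccc21`) is still unmeasured. Its difference from compound 1 is furan-2-yl in place of acetyl on an oxygen on an unsaturated carbon and amounts to furan-2-yl in place of acetyl on an oxygen on an unsaturated carbon.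

Within the data shown here, no measured pair differs in one place, so the size of such a swap has no direct precedent. The expectation in this assay is therefore a weak one: a modest move toward stronger inhibition, only slightly beyond the scatter and with no firm support for its direction. The expected shift is the estimated step of a 2.6-fold lower number from compound 1 to compound 3 (0.41 log units; beyond the scatter) on this reading. Compound 3 is estimated at 15000 nM with an expected range of 4000 nM to 50000 nM for the measurement.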

Compound 3, half-maximal inhibitory concentration: 53400 nM
The estimate for compound 3 lay 3.6-fold (0.55 log units) below the measured number; the whole stated range lies below it.
By their numbers in this assay, from the lowest: compounds 2, 1 and 3 (each within the scatter of the next, the first and the last beyond it).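

In this assay, within the data shown here, furan-2-yl in place of acetyl on an oxygen on an unsaturated carbon gives a 1.4-fold higher number from compound 1 to compound 3 (0.14 log units; within the scatter), the first one-place step that can be read. At this position, therefore, a five-membered aromatic ring can enter where no ring stood, and the read-out stays within the scatter, so acetoxy and (furan-2-yl)oxy stand level and neither can be ranked above the other. Nothing measured bears on why the two groups read alike, and the level result stands here as an observation only.

One step within the scatter does not show whether this position is generally indifferent to what sits on the oxygen, and the compounds shown leave open whether an aminoethyl chain, a benzoyl group or a longer acyl chain such as hexanoyl would move the number beyond the scatter. From the compounds shown here alone, compound 2 differs from compound 1 in more than one place, so it adds nothing on this position, and whether the same swap would read alike on another core also remains open.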